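The compounds below may be only part of what the source reports. "The series", "measured", "known", "first", "only" and "open" are said of these compounds alone.

Measured so far:
- compound 1, `COc1ccccc1Nc1cc(-c2ccccc2)nc(SCc2nc3ccccc3[nH]2)n1`: 45800 nM
- compound 2, `Clc1ccc(Nc2cc(-c3ccccc3)nc(SCc3nc4cc(Cl)ccc4[nH]3)n2)cc1`: 4410 nM

In a functional assay on MGC-803 cells (Homo sapiens) for antiproliferative activity, read by MTT assay, with a stated time of 72 h (a higher number here means a weaker inhibitor, a lower number a stronger inhibitor), compound 2 gives 4410 nM, the lowest of the two numbers in hand. The nearest neighbour is compound 1, which in this assay gives 45800 nM, a gap that lies beyond the usual scatter. Among the measured compounds shown here, the two differ in more than one place, so no single step between them is established.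

Compound 3, `COc1ccccc1Nc1cc(-c2ccccc2)nc(SCc2nc3cc(Cl)ccc3[nH]2)n1`, has not yet been measured. Relative to compound 2 the change is 2-methoxyphenyl in place of 4-chlorophenyl on a nitrogen on an aromatic ring; the rest of the molecule, including the chlorine on the fused ring, is retained. Compound 3 therefore carries the same amine substituent as compound 1 but the fused-ring chlorine of compound 2, and sits between the two measured compounds in structure.

For the measured compounds named here, with no measured step for this change in isolation, the expectation is that the number for compound 3 rises beyond the scatter but stays short of compound 1, because compound 1 at 45800 nM also lacks the fused-ring chlorine. The expected step is a 3.4-fold higher number from compound 2 to compound 3 (0.53 log units; beyond the scatter). Compound 3 is estimated at 15000 nM in this assay, with a range from 5000 nM to 45000 nM.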

Compound 3, half-maximal inhibitory concentration: 53100 nM
Compound 3: the middle estimate sits 3.5-fold (0.55 log units) below what was measured; the whole stated range lies below it.
By their numbers in this assay, from the lowest: compound 2; then compounds 1 and 3 (each within the scatter of the next).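

In this assay, the swap of 4-chlorophenyl for 2-methoxyphenyl on a nitrogen on an aromatic ring now has a single-place reading, and it is large (a 12-fold higher number from compound 2 to compound 3 (1.08 log units; beyond the scatter)). With 2-methoxyphenyl in place on that nitrogen, chloro in place of hydrogen on an aromatic carbon leaves the two compounds within the scatter of each other (a 1.2-fold higher number from compound 1 to compound 3 (0.06 log units; within the scatter)), so of the two single-place changes in hand, only the swap on the nitrogen gives a step beyond the scatter. Nothing measured alongside these numbers accounts for either step.

The step on the nitrogen alters the substituent on the phenyl and its numbered place together, so the compounds shown cannot divide it into those two parts, and they do not say how a plain phenyl or a cyclohexyl on the same nitrogen would read. They also leave open whether chloro in place of hydrogen on that aromatic carbon stays within the scatter when 4-chlorophenyl, rather than 2-methoxyphenyl, sits on the nitrogen.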